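The compounds below may be only part of what the source reports. "The series", "measured", "known", "first", "only" and "open" are said of these compounds alone.

In a physicochemical assay for permeability, using PAMPA (on this read-out higher numbers stand for higher permeability and lower numbers for lower permeability), compound 3 (`CCOc1cc2oc(=O)n(CCC(=O)O)c2cc1Cl`) holds only a limit, < 10 nm/s, so its true position is open. In this assay compound 2 (`O=C(O)CCn1c(=O)oc2cc(OCc3ccccc3)c(Cl)cc21`) stands as "not determined" (no result reported) and adds nothing to the comparison. Within the data shown here, the only number comes from compound 1 (`Cc1ccc([C@@H](C)Oc2cc3oc(=O)n(CCC(=O)O)c3cc2Cl)nc1`), which reads 22 nm/s.

Compound 4 (`Cc1cccc([C@@H](C)Oc2cc3oc(=O)n(CCC(=O)O)c3cc2Cl)n1`) differs from compound 3 as follows: 6-methylpyridin-2-yl in place of hydrogen on a saturated chain carbon bound to an oxygen on an aromatic ring and a saturated chain carbon. Compound 1 carries 5-methylpyridin-2-yl on that same saturated chain carbon, so compound 4 has the closest measured comparison in compound 1, with 6-methylpyridin-2-yl as the group that differs.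

Among the measured compounds shown here, one measured step bears on the change, and it runs the opposite way: an at least 2.2-fold lower number from compound 1 to compound 3 (0.34 log units; beyond the scatter). Its size is a bound only, due to the limit of < 10 nm/s in this assay, at which 1 of the 3 values shown sits. For the measured compounds named here, this is a single pair, and no measurement yet shows what 6-methylpyridin-2-yl does in place of 5-methylpyridin-2-yl.

Going by compound 1 at 22 nm/s, the expected move in this assay is upward, of about the same size as that step read in reverse: an at least 2.0-fold higher number from compound 3 to compound 4 (0.30 log units; that floor lies within the scatter). A reading that again returns only a limit remains possible.

For compound 4 the estimated value in this assay is 20 nm/s, with an expected range of 8 nm/s to 50 nm/s.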

Compound 4, apparent permeability: 21 nm/s
Estimate against measurement, compound 4: 1.1-fold (0.02 log units) below, and the stated range covers the measured number.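

In this assay, 6-methylpyridin-2-yl in place of hydrogen on the saturated chain carbon gives an at least 2.1-fold higher number from compound 3 to compound 4 (0.32 log units; beyond the scatter) and adds a second pair at this position, alongside the one carrying 5-methylpyridin-2-yl; the size of this step stays a bound, due to what compound 3 holds: the limit of < 10 nm/s in this assay, at which 1 of the 4 values shown sits. The change to 6-methylpyridin-2-yl in place of 5-methylpyridin-2-yl on that same carbon gives a 1.0-fold lower number from compound 1 to compound 4 (0.02 log units; within the scatter) and does not separate the two groups in this assay. On the compounds shown, the read-out therefore distinguishes either methylpyridinyl group from hydrogen on this carbon, but does not distinguish the two methylpyridinyl groups from each other.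

As far as these compounds go, how far either group truly lies from hydrogen stays open, since compound 3 gives only a limit and not a number. Also open, from the compounds shown here alone, is whether a different substituent on the pyridine ring, such as an amine or trifluoromethyl in place of methyl, would shift the reading, and whether the two groups would still match with a tetrazole in place of the carboxylic acid.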